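The source may report more compounds than this note shows. Statements on the series, on what has been measured and on what is new or still open speak of the compounds shown alone.

Values so far in a physicochemical assay for lipophilicity, at pH 7.4 (on this read-out lower numbers stand for lower lipophilicity and higher numbers for higher lipophilicity), with the compound still open
- compound 1 `CCOc1nc(Nc2ccc(C(=O)NCC(C)(C)O)cc2OC)nc2[nH]ccc12` gives 4.1
- compound 2 `CCOc1nc(Nc2ccc(C(=O)N3C[C@@H](C)O[C@@H](C)C3)cc2OC)nc2[nH]ccc12` gives 5.7
- compound 3 `CCOc1nc(Nc2ccc(C(=O)N3CC4(COC4)C3)cc2OC)nc2[nH]ccc12` is not yet measured

Of the two measured compounds, compound 2 stands higher (5.7). Compound 3 differs from it on a carbonyl carbon (a group of 7 heavy atoms (5 carbon, 1 nitrogen, 1 oxygen; 2 four-membered non-aromatic rings with 1 hetero atom each) in place of a group of 8 heavy atoms (6 carbon, 1 nitrogen, 1 oxygen; one six-membered non-aromatic ring with 2 hetero atoms), on a carbonyl carbon). For the measured compounds named here, only one measured step bears on this change, a large one at the same carbonyl carbon (a number 1.60 log units higher from compound 1 to compound 2 (beyond the scatter)). It shows that swapping the group there can move this number far, but it involves a different incoming group, so it is only a rough guide. A clear fall is expected, smaller than that step (a number 1.00 log units lower from compound 2 to compound 3 (beyond the scatter)). For compound 3 the estimated value is 4.7 (range 4.1 to 5.3).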

Compound 3, distribution coefficient: 4.3
Compound 3: middle estimate off by 0.40 log units, on the high side, and the stated range covers the measured number.
By their numbers in this assay, from the lowest: compounds 1 and 3 (each within the scatter of the next); then compound 2.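

Swapping the 2,6-dimethylmorpholin-4-yl group on the carbonyl carbon for the group with two four-membered rings gives, in this assay, a number 1.40 log units lower from compound 2 to compound 3 (beyond the scatter), so having a ring at this place does not by itself keep the number high. The step of a number 0.20 log units higher from compound 1 to compound 3 (within the scatter) shows that this two-ring group and the open chain of compound 1 cannot be told apart on this read-out. Nothing measured here explains these results. Still open, from the compounds shown here alone, is where a plain morpholine, lacking both methyl groups, would fall at this carbonyl carbon, and whether an azetidine bearing a carboxylic acid would fall elsewhere.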